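The source may report more compounds than this note shows. Statements on the series, on what has been measured and on what is new or still open speak of the compounds shown alone.

Compound 1, `COc1cccc([C@@H](CO)O[C@H]2CCCN(Cc3ccc(C(=O)O)cc3C)[C@H]2c2ccccc2)c1`: in an assay on isolated protein for activation of cGMP-dependent protein kinase 1 (Homo sapiens), read by ADP-Glo, with stated times of 30 min and 2 h (a higher number here means that more compound is needed for the effect, a lower number that less compound is needed), compound 1 gives the limit > 200000 nM.
Compound 2, `COC(=O)c1ccc(CN2CCC[C@H](O[C@H](CO)c3cc(Cl)cc(Cl)c3)[C@@H]2c2ccccc2)c(C)c1`: compound 2 gives the limit > 200000 nM.
Compound 3, `Cc1cc(C(=O)O)ccc1CN1CCC[C@H](O[C@H](CO)c2cc(Cl)cc(Cl)c2)[C@@H]1c1cccc(F)c1`: for compound 3 the entry reads "nd" (no result reported), no result reported.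

Compound 3 therefore stands without a number, and the two companions shown reach only the limit of the method, as the limit of > 200000 nM in this assay, at which 2 of the 3 values shown sit, records. Compound 4, `Cc1cc(C(=O)O)ccc1CN1CCC[C@H](O[C@H](CO)c2cc(Cl)cc(Cl)c2)[C@@H]1C1CCCCC1`, differs from compound 3 by cyclohexyl in place of 3-fluorophenyl on a saturated ring carbon. Going by the values given here, no measured step exists to size this change. With both measured neighbours at the limit, no shift beyond the scatter is expected for compound 4, and the likeliest outcome is again a limit. Compound 4 is estimated at 200000 nM, expected to fall between 50000 nM and 600000 nM.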

Compound 4, half-maximal effective concentration: > 200000 nM
Compound 4 was reported as a limit; the forecaster's own chance of this, stated with the estimate: 80%; the middle value sits exactly at the limit.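

Compound 4 gives > 200000 nM, which is a limit and not a number. With no result for compound 3, no step can be read between compound 3 and compound 4. As far as these compounds go, what swapping 3-fluorophenyl for cyclohexyl does in this assay stays open.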